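Amidine series: sec-butyl in place of methyl on the core

The compounds below may be only part of what the source reports. "The series", "measured", "known", "first", "only" and "open" are said of these compounds alone.

Measured in an assay on isolated protein for inhibition of serine protease 1 (Bos taurus); a higher number here means a weaker inhibitor, a lower number a stronger inhibitor:
compound 1 `CC(=N)N1CCC(Oc2ccc3ncn(Cc4ccc5ccc(C(=N)N)cc5c4)c3c2)CC1`: 50 nM
compound 2 `CC(=N)N1CCC(Oc2ccc3nc(C)n(Cc4ccc5ccc(C(=N)N)cc5c4)c3c2)CC1`: 18 nM

Compound 2 holds the lower of the two numbers; the nearest measured neighbour is compound 1, with a 2.8-fold lower number from compound 1 to compound 2 (0.44 log units; beyond the scatter) separating them, a modest step beyond the scatter. The next compound, compound 3 `CCC(C)c1nc2ccc(OC3CCN(C(C)=N)CC3)cc2n1Cc1ccc2ccc(C(=N)N)cc2c1`, differs from compound 2 in one place: sec-butyl in place of methyl on an aromatic carbon.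

For the measured compounds named here, only one measured step bears on this site. It is a 2.8-fold lower number from compound 1 to compound 2 (0.44 log units; beyond the scatter), which introduced the methyl at the same aromatic carbon of the shared core. Going by the values given here, no measured pair shows what a longer chain at this carbon does, so the direction of a further step there is not supported by any number on hand. The expectation for compound 3 is therefore a step in this assay of a 1.1-fold higher number from compound 2 to compound 3 (0.05 log units; within the scatter), within the scatter. Compound 3 is estimated at 20 nM, with a range from 6 nM to 65 nM.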

Compound 3, inhibition constant: 10 nM
For compound 3 the middle estimate is 2.0-fold (0.30 log units) above the measured one; the measured number falls inside the stated range.
By their numbers in this assay, from the lowest: compounds 3 and 2 (each within the scatter of the next); then compound 1.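

Going from methyl to sec-butyl on this aromatic carbon gives a 1.8-fold lower number from compound 2 to compound 3 (0.26 log units; within the scatter) in this assay, so the larger chain is accepted here, but compound 2 and compound 3 cannot be ranked. Against the unsubstituted core, sec-butyl gives a 5.0-fold lower number from compound 1 to compound 3 (0.70 log units; beyond the scatter), so the gain over hydrogen seen with methyl is retained with a group of 4 heavy atoms. No supporting data on hand account for this outcome.

From the compounds shown here alone, whether this tolerance extends to a longer chain such as n-hexyl, or to a phenyl ring, remains open. A primary amine or a carboxylic acid at the same carbon would show whether the position accepts more than plain alkyl groups.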